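Swapping Nitro for Methoxy: Expected Response of Compound 4

A few compounds are considered here, and "the series" means these few. Any claim that something is new, unique, unknown or untested is made for them only; others in the source may bear on it.

compound 1 `FC(F)(F)c1ccc2[nH]c(-c3ccccc3)nc2c1`: 75.6%
compound 2 `Oc1ccc(-c2nc3cc(C(F)(F)F)ccc3[nH]2)cc1`: 37%
compound 3 `O=[N+]([O-])c1ccccc1-c1nc2cc(C(F)(F)F)ccc2[nH]1`: 85.3%

In a functional assay on aorta (Rattus norvegicus, strain Wistar) for inhibition, with a stated time of 60 min (on this read-out lower numbers stand for smaller maximal responses and higher numbers for larger maximal responses), compound 3 gives 85.3%, the highest of the three numbers. Its nearest neighbour is compound 1, and the step of a number 9.7 percentage points higher from compound 1 to compound 3 (within the scatter) stays within the scatter, whereas the step of a number 38.6 percentage points lower from compound 1 to compound 2 (beyond the scatter) is large. Compound 4 `COc1ccccc1-c1nc2cc(C(F)(F)F)ccc2[nH]1` differs from compound 3 by methoxy in place of nitro on an aromatic carbon. For the measured compounds named here, no measured step shows a methoxy: the hydroxy step was large and the nitro step was small, and neither group sits ortho to a large group as the methoxy does. A modest fall is therefore expected, a number 13.3 percentage points lower from compound 3 to compound 4 (beyond the scatter), with a wide range of uncertainty. Compound 4 is estimated at 72%, between 50% and 90%.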

Compound 4, largest response reached (Emax), in percent of the reference or control that the assay uses: 45.7%
Estimate against measurement, compound 4: 26.3 percentage points above; measured number below the stated range.
By their numbers in this assay, from the lowest: compounds 2 and 4 (each within the scatter of the next); then compounds 1 and 3 (each within the scatter of the next).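

In this assay, this place, ortho to a large group, turns out to be sensitive to which group sits there: methoxy in place of nitro gives a number 39.6 percentage points lower from compound 3 to compound 4 (beyond the scatter), and methoxy in place of hydrogen gives a number 29.9 percentage points lower from compound 1 to compound 4 (beyond the scatter). Nitro at the same place had moved the number by no more than the scatter, so the earlier compounds made this position look less responsive than it is. Nothing available explains why these two groups differ. Going by these compounds, it remains open whether an amine or a carboxylic acid at this place would follow methoxy or nitro, and whether methoxy on another carbon of this ring would give a similar step.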